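The compounds below may be only part of what the source reports. "The series", "measured", "known", "first", "only" and "open" are said of these compounds alone.

Measured so far in a functional assay on the whole organism with Rattus norvegicus as the target; on this read-out lower numbers stand for an effect already at smaller amounts and higher numbers for an effect only at larger amounts of compound:
compound 1 `CCc1c(OC)nc2nc(-c3nnc(C)o3)cn2c1C` gives 2 mg/kg
compound 2 `CCc1c(OC)nc2nc(-c3nc(C)cs3)cn2c1C` reaches only the assay limit of > 50 mg/kg
compound 3 `CCc1csc(-c2cn3c(C)c(CC)c(OC)nc3n2)n1` gives 50 mg/kg

Compound 3 carries the highest of the two numbers seen in this assay; compound 1 is the nearest and sits well below it, and compound 2 sits at a limit (the limit of > 50 mg/kg in this assay, at which 1 of the 3 values shown sits). The steps from compound 1 read an at least 25-fold higher number from compound 1 to compound 2 (1.39 log units; beyond the scatter) and a 25-fold higher number from compound 1 to compound 3 (1.40 log units; beyond the scatter), both large; a number no higher from compound 2 to compound 3 (the limit leaves the size open) cannot be sized.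

Compound 4 `CCc1c(OC)nc2nc(-c3nc(C)no3)cn2c1C` differs from compound 3 by 3-methyl-1,2,4-oxadiazol-5-yl in place of 4-ethyl-1,3-thiazol-2-yl on an aromatic carbon. This reverses the sense of the step to compound 3, putting an oxadiazole back where the thiazole was, though a different isomer. A large drop in the number is therefore expected, a 17-fold lower number from compound 3 to compound 4 (1.22 log units; beyond the scatter). Compound 4 is estimated at 3 mg/kg, within 1 mg/kg to 15 mg/kg.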

Compound 4, minimum effective dose: 5 mg/kg
Estimate against measurement, compound 4: 1.7-fold (0.22 log units) below; the measured number falls inside the stated range.
By their numbers in this assay, from the lowest: compound 1; then compound 4; then compound 3.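

With 3-methyl-1,2,4-oxadiazol-5-yl at this position, a second oxadiazole isomer gives a low number, not only 5-methyl-1,3,4-oxadiazol-2-yl: a 10-fold lower number from compound 3 to compound 4 (1.00 log units; beyond the scatter). The step of an at least 10-fold lower number from compound 2 to compound 4 (1.00 log units; beyond the scatter) rests on a limit of the assay: the limit of > 50 mg/kg in this assay, at which 1 of the 4 values shown sits. The two isomers are still not interchangeable, with a 2.5-fold higher number from compound 1 to compound 4 (0.40 log units; beyond the scatter).

Going by these compounds, whether an ethyl group or a longer chain on the oxadiazole, or an amine in place of its methyl, keeps the number low remains open. The whole-organism read-out alone does not show what separates the oxadiazoles from the thiazoles.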